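The source may report more compounds than this note shows. Statements on the series, on what has been measured and on what is new or still open speak of the compounds shown alone.

Measured so far in a functional assay on cells (leukaemia cell line, Homo sapiens) for inhibition, read by sulforhodamine B assay, with a stated time of 48 h; on this read-out higher numbers stand for weaker inhibition of growth and lower numbers for stronger inhibition of growth

Compound 1 `O=S(=O)(Nc1ccc(Cl)c(F)c1)c1ccc(-c2cnc(C3CC3)o2)cc1` gives 63000 nM
Compound 2 `Cc1cc(NS(=O)(=O)c2ccc(-c3cnc(C4CC4)o3)cc2)ccc1Cl` gives 33400 nM
Compound 3 `Cc1ccc(NS(=O)(=O)c2ccc(-c3cnc(C4CC4)o3)cc2)cc1C` gives > 100000 nM as a limit of the assay

Compound 3 has only a limit to show, and so it stands at the limit of > 100000 nM in this assay, at which 1 of the 3 values shown sits, in this small set. Compound 4 `Cc1ccc(Cl)c(NS(=O)(=O)c2ccc(-c3cnc(C4CC4)o3)cc2)c1` carries 2-chloro-5-methylphenyl in place of 3,4-dimethylphenyl on a sulfonamide nitrogen. The closest measured precedent is methyl in place of chloro on an aromatic carbon (an at least 2.9-fold higher number from compound 2 to compound 3 (0.47 log units; beyond the scatter)). Compound 4 brings a chloro group back, and that step is read here in reverse. A weaker hint comes from the exchange of the 4-chloro-3-fluorophenyl group for 3,4-dimethylphenyl (an at least 1.5-fold higher number from compound 1 to compound 3 (0.20 log units; that floor lies within the scatter)). Methyl in place of fluoro adds little (a 1.9-fold lower number from compound 1 to compound 2 (0.28 log units; within the scatter)). Among the measured compounds shown here, no measured compound carries 2-chloro-5-methylphenyl, so the range stays wide. A modest move to a lower number is expected, and the estimated change is an at least 2.0-fold lower number from compound 3 to compound 4 (0.30 log units; that floor lies within the scatter) in this assay terms. For compound 4 the estimate is 50000 nM (expected range 18000 nM to 100000 nM).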

Compound 4, concentration for total growth inhibition: 52800 nM
Compound 4: the middle estimate sits 1.1-fold (0.02 log units) below what was measured; measured number inside the range.
By their numbers in this assay, from the lowest: compounds 2, 4 and 1 (each within the scatter of the next). At a limit, above all of these: compound 3.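

In this assay, the 2-chloro-5-methylphenyl group on the sulfonamide nitrogen cannot be told apart from the 4-chloro-3-methylphenyl group, a 1.6-fold higher number from compound 2 to compound 4 (0.20 log units; within the scatter), or from the 4-chloro-3-fluorophenyl group, a 1.2-fold lower number from compound 1 to compound 4 (0.08 log units; within the scatter), so the read-out does not separate these three substitution patterns. Against the 3,4-dimethylphenyl group only a floor can be given, an at least 1.8-fold lower number from compound 3 to compound 4 (0.27 log units; that floor lies within the scatter), and that floor does not show a real gain on its own. Compound 3, the one compound here without chloro, has only a limit of the assay to show: the limit of > 100000 nM in this assay, at which 1 of the 4 values shown sits.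

The compounds shown leave open whether the chloro group itself is what separates compound 2 from compound 3, and how a methoxy group or a carboxylic acid in its place would read. They also leave open how the plain phenyl group would compare.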